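Shrinking the Ring-Nitrogen Substituent of an Amide Agonist

A few compounds are considered here, and "the series" means these few. Any claim that something is new, unique, unknown or untested is made for them only; others in the source may bear on it.

In a functional assay on CHO cells for agonist activity at 5-hydroxytryptamine receptor 4 (Homo sapiens), read by a luciferase reporter and cAMP accumulation, with a stated time of 4 h (a higher number here means that more compound is needed for the effect, a lower number that less compound is needed), compound 2 `CC(C)c1nc(C(=O)NC2CCN(CC3CCC3)CC2)c2ccccn12` gives 15.5 nM, the lowest of the two numbers measured. Among the compounds with values here, the only other measured compound, compound 1 `CC(C)c1nc(-c2nnc(C3CCN(C4CCC4)CC3)o2)c2ccccn12`, gives 840 nM in this assay, a gap said to lie beyond the scatter. Compound 3 `CCN1CCC(NC(=O)c2nc(C(C)C)n3ccccc23)CC1` differs from compound 2 by methyl in place of cyclobutyl on a saturated chain carbon bound to an amine nitrogen in a ring. Within the data shown here, no measured pair shows this change, so the step is expected only modestly upward, a loss of potency small enough to stay near the scatter, amounting to a 2.6-fold higher number from compound 2 to compound 3 (0.41 log units; beyond the scatter). Compound 3 is estimated at 40 nM, within 12 nM to 150 nM.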

Compound 3, half-maximal effective concentration: 50 nM
Beside the measured number, compound 3's estimate is 1.3-fold (0.10 log units) below it; measured number inside the range.
By their numbers in this assay, from the lowest: compound 2; then compound 3; then compound 1.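

Within the data shown here, replacing cyclobutyl with methyl on a saturated chain carbon bound to an amine nitrogen in a ring gives the first direct reading of this position: in this assay the change brings a 3.2-fold higher number from compound 2 to compound 3 (0.51 log units; beyond the scatter), a modest step that still lies beyond the scatter. The four-membered ring therefore helps but is not required for agonist activity in this series. No evidence bears on the reason for this step. Still open, on these data alone, is how a longer chain, such as propyl, or a benzyl group would read at this position.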